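Pyridine ring returned with a hydroxyl group on the thiazole core

The source may report more compounds than this note shows. Statements on the series, on what has been measured and on what is new or still open speak of the compounds shown alone.

Within the data shown here, compound 2 `O=C(O)Cc1sc(C(c2ccc(F)cc2)c2ccc(F)cc2)nc1-c1ccc(Cl)cc1` gives 180 nM in an in vitro functional assay on HEK285-7 cells for antagonist activity at prostaglandin D2 receptor 2 (Homo sapiens), read by BRET and beta-arrestin recruitment (a higher number here means a weaker inhibitor, a lower number a stronger inhibitor), and stands as the higher of the two numbers so far. Among the measured compounds shown here, compound 1 `O=C(O)Cc1sc(C(c2ccc(F)cc2)c2ccc(F)cc2)nc1-c1ccnc(Cl)c1` gives 39 nM, and the only measured step, a 4.6-fold higher number from compound 1 to compound 2 (0.66 log units; beyond the scatter), separates the two. Compound 3 `O=C(O)Cc1sc(C(c2ccc(F)cc2)c2ccc(F)cc2)nc1-c1ccnc(O)c1` has not been measured; it differs from compound 2 by 2-hydroxypyridin-4-yl in place of 4-chlorophenyl on an aromatic carbon. For the measured compounds named here, the one step that bears on this change is the one from compound 1, where a 2-chloropyridin-4-yl gave way to a 4-chlorophenyl and the number rose by a 4.6-fold higher number from compound 1 to compound 2 (0.66 log units; beyond the scatter). As far as these compounds go, compound 3 brings a pyridine ring back, though with a hydroxyl where compound 1 carried a chlorine, so the effect of that hydroxyl is unknown. Compound 3 is therefore expected to move back toward a lower number, by about a 3.0-fold lower number from compound 2 to compound 3 (0.48 log units; beyond the scatter). Compound 3 is estimated at 60 nM, with a range of 20 nM to 200 nM.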

Compound 3, half-maximal inhibitory concentration: 890 nM
Beside the measured number, compound 3's estimate is 15-fold (1.17 log units) below it; measured number outside the range, above it.
By their numbers in this assay, from the lowest: compound 1; then compound 2; then compound 3.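

At the 2-position of the pyridin-4-yl group, the choice of substituent matters greatly in this assay: hydroxy in place of chloro gives a 23-fold higher number from compound 1 to compound 3 (1.36 log units; beyond the scatter). The gain seen with 2-chloropyridin-4-yl over 4-chlorophenyl therefore does not belong to the pyridine ring alone, since 2-hydroxypyridin-4-yl in place of 4-chlorophenyl gives a 4.9-fold higher number from compound 2 to compound 3 (0.69 log units; beyond the scatter), the opposite direction to the step between those two chlorinated compounds. No supporting data are available to explain this reversal.

The three compounds leave open whether the loss follows from removing the chlorine or from adding the hydroxyl, a question that a pyridin-4-yl ring with only hydrogen at that position would address. As far as these compounds go, it also remains open whether a methoxy group, an amine or a fluorine there would stay close to compound 1 or fall toward compound 3.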